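Isobutyl in place of 4-methylphenyl on the core of compound 1

This account rests on a few compounds, and the source may have more. Where it says the series, first, only, none or still open, it means among the compounds named here.

Three compounds of this series have so far been measured in a functional assay on SW480 cells (Homo sapiens) for cytotoxicity, read by MTT assay, with a stated time of 24 h; on this read-out lower numbers stand for stronger inhibition and higher numbers for weaker inhibition:

compound 1, `C=CC1=C(C(=O)Nc2ccc(C)cc2)C(c2ccc(F)cc2)OC1`: > 100000 nM
compound 2, `C=CC1=C(C(=O)Nc2ccc(C)cc2)C(c2ccc(OC)cc2)OC1`: > 100000 nM
compound 3, `C=CC1=C(C(=O)O)C(c2ccc(Cl)c(Cl)c2)OC1`: > 100000 nM

Compound 1 stands only at a limit of this assay, > 100000 nM, not at a number. Compound 2 likewise gives only a limit, > 100000 nM. Compound 3 also returns only a limit, > 100000 nM. All three values therefore sit on the same line, (the limit of > 100000 nM in this assay, at which 3 of the 3 values shown sit). For the measured compounds named here, the one step between measured compounds that differ in a single place, a step that the two limits leave unreadable from compound 1 to compound 2, is thus unreadable in size, a methoxy in place of fluoro on an aromatic carbon.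

Compound 4, `C=CC1=C(C(=O)NCC(C)C)C(c2ccc(F)cc2)OC1`, differs from compound 1 at the amide-type nitrogen: isobutyl in place of 4-methylphenyl on an amide-type nitrogen. None of the measured steps touches that position, so no measured step bears on this change, and the only step shown is itself unreadable. The expectation for a number no higher from compound 1 to compound 4 (the limit leaves the size open) is therefore no readable shift beyond the scatter, with compound 4 most likely remaining at the limit of this assay. Compound 4 is estimated in this assay at 100000 nM, with a range from 40000 nM to 300000 nM.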

Compound 4, half-maximal inhibitory concentration: > 100000 nM
Compound 4: only a limit was reported; the forecaster's own chance of this, stated with the estimate: 80%; the middle value sits exactly at the limit.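

In this assay compound 4 returns only a limit, > 100000 nM. For the compounds shown here, compound 1 also stands at a limit, so no step between compound 1 and compound 4 can be read: the limit of > 100000 nM in this assay, at which 4 of the 4 values shown sit. The compounds shown leave open whether any change on the shared core would yield a measurable value in this assay.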